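Furanone ring change on fluorocinnamanilides and topoisomerase inhibition

The source may report more compounds than this note shows. Statements on the series, on what has been measured and on what is new or still open speak of the compounds shown alone.

Measured compounds:
compound 1 `O=C(/C=C/c1cccc(F)c1)Nc1ccc(CC2=CC(=O)OC2)cc1`: 13.1%
compound 2 `C=C1OC(=O)C=C1Cc1ccc(NC(=O)/C=C/c2cccc(F)c2)cc1`: 34.5%
compound 3 `O=C(/C=C/c1ccc(F)cc1)Nc1ccc(CC2=CC(=O)OC2)cc1`: 12.1%

Three compounds were tested in an assay on isolated protein for inhibition of DNA topoisomerase 1 (Homo sapiens), with a stated time of 30 min, tested at 100 uM; on this read-out higher numbers stand for more inhibition at the one concentration tested (going by the name of the read-out) and lower numbers for less inhibition. Compound 1 `O=C(/C=C/c1cccc(F)c1)Nc1ccc(CC2=CC(=O)OC2)cc1` gives 13.1% in this assay. Compound 2 `C=C1OC(=O)C=C1Cc1ccc(NC(=O)/C=C/c2cccc(F)c2)cc1` differs from compound 1 by one change, (a group of 7 heavy atoms (5 carbon, 2 oxygen; one five-membered non-aromatic ring with 1 hetero atom) in place of a group of 6 heavy atoms (4 carbon, 2 oxygen; one five-membered non-aromatic ring with 1 hetero atom), on a saturated chain carbon bound to an aromatic carbon). In this assay compound 2 gives 34.5%. That change made a step of a number 21.4 percentage points higher from compound 1 to compound 2 (beyond the scatter). Compound 3 `O=C(/C=C/c1ccc(F)cc1)Nc1ccc(CC2=CC(=O)OC2)cc1` differs from compound 1 in the fluorophenyl part, (4-fluorophenyl in place of 3-fluorophenyl on a double-bonded chain carbon bound to a double-bonded chain carbon). In this assay compound 3 gives 12.1%; the step of a number 1 percentage points lower from compound 1 to compound 3 (within the scatter) lies within the scatter, so compound 1 and compound 3 are not told apart here.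

Compound 4 `C=C1OC(=O)C=C1Cc1ccc(NC(=O)/C=C/c2ccc(F)cc2)cc1` has not yet been measured in this assay. It stands to compound 3 as compound 2 stands to compound 1: the difference is a group of 7 heavy atoms (5 carbon, 2 oxygen; one five-membered non-aromatic ring with 1 hetero atom) in place of a group of 6 heavy atoms (4 carbon, 2 oxygen; one five-membered non-aromatic ring with 1 hetero atom), on a saturated chain carbon bound to an aromatic carbon, the same change as that from compound 1 to compound 2, occurring twice among these compounds. The two cores differ only by 4-fluorophenyl in place of 3-fluorophenyl on a double-bonded chain carbon bound to a double-bonded chain carbon.

Since compound 1 and compound 3 are indistinguishable in this assay and the same ring change produced the step of a number 21.4 percentage points higher from compound 1 to compound 2 (beyond the scatter), a step of about a number 20.9 percentage points higher from compound 3 to compound 4 (beyond the scatter) is expected from compound 3 to compound 4. Compound 4 is therefore estimated at 33% in this assay, expected to fall between 18% and 48%.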

Compound 4, a percentage reported as inhibition, at one concentration (the size of the read-out at that concentration, not a potency): 94.1%
Beside the measured number, compound 4's estimate is 61.1 percentage points below it; measured number above the stated range.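

On the 4-fluorophenyl core, the group of 7 heavy atoms in place of the group of 6 heavy atoms gave in this assay a step of a number 82 percentage points higher from compound 3 to compound 4 (beyond the scatter), so the ring change raised the number on both cores but did not carry over at the same size: the same change on two cores in this assay, a number 21.4 percentage points higher (beyond the scatter) from compound 1 to compound 2 and a number 82 percentage points higher (beyond the scatter) from compound 3 to compound 4, 60.6 percentage points apart, beyond the scatter of two such steps

Seen from the other side, 4-fluorophenyl in place of 3-fluorophenyl gave a number 59.6 percentage points higher from compound 2 to compound 4 (beyond the scatter) when the group of 7 heavy atoms was present, although it left the numbers of the other pair unresolved: the same change on two cores in this assay, a number 1 percentage points lower (within the scatter) from compound 1 to compound 3 and a number 59.6 percentage points higher (beyond the scatter) from compound 2 to compound 4, 60.6 percentage points apart, beyond the scatter of two such steps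

The two changes therefore do not act independently in these four compounds, but this rests on a single pair per core at one concentration, so it gives neither a rule for other cores nor a ranking of potency, and the data do not tell why the steps differ.

As far as these compounds go, it remains open whether the large step in this assay is peculiar to the fluorine-bearing 4-fluorophenyl group or would also appear with a chlorophenyl, a methoxyphenyl or a plain phenyl group on the same double-bonded chain carbon. How compound 4 would behave across a range of concentrations, and whether a saturated five-membered ring carrying a methyl group would retain its number, also stay unanswered.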